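Amine tail change in the dichlorothienopyrimidine urea series

A few compounds are considered here, and "the series" means these few. Any claim that something is new, unique, unknown or untested is made for them only; others in the source may bear on it.

Measured compounds:
compound 1 `CN(C)CCCNc1nc(-c2ccc(NC(=O)Nc3ccc(F)cc3)cc2)nc2c(Cl)c(Cl)sc12` — 650 nM
compound 2 `CN(C)CCCNc1nc(-c2ccc(NC(=O)Nc3ccc(Cl)cc3Cl)cc2)nc2c(Cl)c(Cl)sc12` — 980 nM

In a functional assay on NCI-H460 cells (Homo sapiens) for cytotoxicity, read by MTT assay, with a stated time of 72 h (a lower number here means a stronger inhibitor, a higher number a weaker inhibitor), compound 1 gives 650 nM, the lowest of the two numbers shown. Compound 2 gives 980 nM, and the step of a 1.5-fold higher number from compound 1 to compound 2 (0.18 log units; within the scatter) lies within the scatter. Compound 3 `CCN(CC)CCNc1nc(-c2ccc(NC(=O)Nc3ccc(F)cc3)cc2)nc2c(Cl)c(Cl)sc12` differs from compound 1 by diethylamino in place of (dimethylamino)methyl on a saturated chain carbon, two bonds along the chain from a nitrogen on an aromatic ring. For the measured compounds named here, no measured step touches this part of the molecule; the only step available, a 1.5-fold higher number from compound 1 to compound 2 (0.18 log units; within the scatter), alters the aryl on the urea and is within the scatter, so it gives no direction. No step beyond the scatter is expected: no change at the digits printed from compound 1 to compound 3 (within the scatter). Compound 3 is therefore estimated at 650 nM, with a range of 300 nM to 1500 nM.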

Compound 3, half-maximal inhibitory concentration: 500 nM
The estimate for compound 3 lay 1.3-fold (0.11 log units) above the measured number, within the range that was stated.
By their numbers in this assay, from the lowest: compounds 3, 1 and 2 (each within the scatter of the next).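

In this assay the amine tail gets its first reading: 3-(dimethylamino)propyl changed to 2-(diethylamino)ethyl gives a 1.3-fold lower number from compound 1 to compound 3 (0.11 log units; within the scatter) on the 4-fluorophenyl urea. This position therefore accepts this exchange of tail without a shift beyond the scatter, in this one pair. No measured evidence bears on this result.

As far as these compounds go, whether a ring amine such as morpholine or piperidine, or a tail ending in a carboxylic acid, stays in the same range remains open. Also open, from the compounds shown here alone, is whether the same tail change reads alike with the 2,4-dichlorophenyl urea of compound 2.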